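A few compounds are considered here, and "the series" means these few. Any claim that something is new, unique, unknown or untested is made for them only; others in the source may bear on it.

Measured in a physicochemical assay for solubility, with a stated time of 24 h, at pH 6.8; on this read-out higher numbers stand for higher solubility and lower numbers for lower solubility:

- Compound 1 `O=C(NC[C@@H]1[C@H]2CN(C(=O)CCc3cc(Cl)cc(Cl)c3)C[C@@H]12)c1ccc2[nH]c(=O)oc2c1`: < 1 ug/mL, a limit of the assay and not a number
- Compound 2 `Cc1ccc(COC(=O)N2C[C@@H]3[C@@H](CNC(=O)c4ccc5[nH]c(=O)oc5c4)[C@@H]3C2)nc1`: 56 ug/mL

Among the compounds with values here, compound 2 holds the only real number so far, 56 ug/mL. Compound 1 gave only a limit.

Compound 3 `Cc1cc(COC(=O)N2C[C@@H]3[C@@H](CNC(=O)c4ccc5[nH]c(=O)oc5c4)[C@@H]3C2)no1` differs from compound 2 in one place: 5-methyl-1,2-oxazol-3-yl in place of 5-methylpyridin-2-yl on a saturated chain carbon bound to an oxygen next to a carbonyl group.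

Within the data shown here, only one measured step can serve as a guide, an at least 56-fold higher number from compound 1 to compound 2 (1.74 log units; beyond the scatter), and it was large. In that step, a group on a carbonyl carbon with a ring of carbon only gave way to one whose ring holds a hetero atom. In the new change, both the leaving and the entering ring hold hetero atoms, so the earlier step is only a loose guide and gives no direction. No step beyond the scatter is therefore expected in this assay. The estimated step is a 1.1-fold higher number from compound 2 to compound 3 (0.03 log units; within the scatter). The expected value for compound 3 is 60 ug/mL, with an estimated range from 20 ug/mL to 180 ug/mL.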

Compound 3, solubility: 63 ug/mL
The estimate for compound 3 lay 1.1-fold (0.02 log units) below the measured number; the measured number falls inside the stated range.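

In this assay, putting 5-methyl-1,2-oxazol-3-yl in place of 5-methylpyridin-2-yl, on a saturated chain carbon bound to an oxygen next to a carbonyl group, gives a 1.1-fold higher number from compound 2 to compound 3 (0.05 log units; within the scatter); this place therefore takes a five-membered aromatic ring as well as a six-membered one, without a change that can be read. A second group of this kind also stands far from the dichlorophenyl compound, with (5-methyl-1,2-oxazol-3-yl)methoxy in place of 2-(3,5-dichlorophenyl)ethyl on a carbonyl carbon giving an at least 63-fold higher number from compound 1 to compound 3 (1.79 log units; beyond the scatter), so the large step no longer rests on the pyridine ring alone. Its size is tied to a limit and not a number: the limit of < 1 ug/mL in this assay, at which 1 of the 3 values shown sits.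

The compounds shown do not separate the two chlorine atoms, the carbon-only ring and the oxygen in the link as parts of the large steps. A plain phenyl on the same oxygen-linked chain would help to pull these apart. On these data alone, how a ring carrying an amine or a carboxylic acid would read in this assay also remains open.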